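This account rests on a few compounds, and the source may have more. Where it says the series, first, only, none or still open, it means among the compounds named here.

Compound 1 `CCc1ccc(Cl)cc1-n1cc(-c2ncnn3cccc23)cc1C(N)=O`: 5.5 h
Compound 2 `CCc1ccc(Cl)cc1-n1cc(-c2cc(N)ncn2)cc1C(N)=O`: 2 h

Both numbers come from an ADME assay on the whole organism (strain Balb) for metabolic stability, with Mus musculus as the target, read by LC-MS, at a dose of 10 mg/kg by the intravenous route (a lower number here means that the compound disappears faster, a higher number that the compound lasts longer), a measure of how long a compound stays in the animal after dosing. Compound 2 has the lower half-life of the pair at 2 h, while compound 1 gives 5.5 h, a gap beyond the usual scatter of repeated measurements.

Compound 3 `CCc1ccc(Cl)cc1-n1cc(-c2cc(NC)ncn2)cc1C(N)=O` keeps all of compound 2 except for one small change: methyl in place of hydrogen on a nitrogen on an aromatic ring. This is methyl in place of hydrogen on a nitrogen on an aromatic ring, which turns amino to methylamino. Compound 1 and compound 2 differ by more than this single change, so the measured pair gives no direct guide to its effect. Without such a guide, the starting point is the half-life of compound 2, 2 h, and no step beyond the scatter is expected in this assay. The expected step, a 1.1-fold lower number from compound 2 to compound 3 (0.05 log units; within the scatter), is small, and its direction is uncertain. The estimated half-life of compound 3 is 1.8 h, with an expected range of 0.9 h to 3.5 h.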

Compound 3, half-life: 5.4 h
Estimate against measurement, compound 3: 3.0-fold (0.48 log units) below; measured number outside the range, above it.
By their numbers in this assay, from the lowest: compound 2; then compounds 3 and 1 (each within the scatter of the next).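

In this assay, putting methyl in place of hydrogen on a nitrogen on an aromatic ring gives a 2.7-fold higher number from compound 2 to compound 3 (0.43 log units; beyond the scatter), a modest step but a real one. Among these compounds, this is the first direct reading of a single change at this position, and it shows that the half-life in the animal responds to even the small switch from amino to methylamino, something the earlier pair, which differs by more than one change, could not isolate. The data offer no measurement that would explain why the half-life responds to this change.

From the compounds shown here alone, what remains open is whether the trend continues with a longer chain such as ethyl, or with dimethylamino, where both hydrogens on that nitrogen are replaced, or whether the gain stops at methyl. This is also a single pair on a single core, so it cannot show whether the same swap would give a similar step with a different group on the shared core, such as a fluorine in place of the chlorine.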